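The source may hold more compounds than are shown below. What is called first, only, known or untested is meant among the compounds shown, and "the series" means these compounds.

Compound 1 `Fc1cccnc1N1CCN(Cc2nc3ccccc3[nH]2)CC1` gives 24 nM in an assay on HEK293 cells with D(4) dopamine receptor (Homo sapiens) as the target, read by FLIPR; a higher number here means that more compound is needed for the effect, a lower number that less compound is needed. Among the three measured compounds it holds the second highest number. Its nearest neighbour is compound 2 `Fc1ccccc1N1CCN(Cc2nc3ccccc3[nH]2)CC1`, which in this assay gives 14.7 nM; the step of a 1.6-fold lower number from compound 1 to compound 2 (0.21 log units; within the scatter) does not separate the two. Compound 3 `CSc1ccccc1N1CCN(Cc2nc3ccccc3[nH]2)CC1` lies furthest away, giving 86 nM in this assay, with the step of a 3.6-fold higher number from compound 1 to compound 3 (0.55 log units; beyond the scatter).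

Compound 4 `CS(=O)(=O)c1cccnc1N1CCN(Cc2nc3ccccc3[nH]2)CC1` has not been measured. It differs from compound 1 in one place: methylsulfonyl in place of fluoro on an aromatic carbon.

Among the compounds with values here, the measured step that bears most directly on this change is the one from compound 2 to compound 3, a 5.9-fold higher number from compound 2 to compound 3 (0.77 log units; beyond the scatter), where a methylsulfanyl likewise took the place of a fluoro on an aromatic carbon. The step of a 3.6-fold higher number from compound 1 to compound 3 (0.55 log units; beyond the scatter) points the same way, though there the whole aryl group is exchanged. Both steps raise the number, so a higher number for compound 4 in this assay is the expectation; whether methylsulfonyl shifts it more or less than methylsulfanyl cannot be told from the compounds in hand, and the range is set wide.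

Compound 4 is therefore estimated at 110 nM in this assay, between 35 nM and 350 nM. This estimate means an expected step of a 4.6-fold higher number from compound 1 to compound 4 (0.66 log units; beyond the scatter).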

Compound 4, half-maximal effective concentration: 136 nM
Compound 4: middle estimate off by 1.2-fold (0.09 log units), on the low side; the measured number falls inside the stated range.
By their numbers in this assay, from the lowest: compounds 2 and 1 (each within the scatter of the next); then compounds 3 and 4 (each within the scatter of the next).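

At the aromatic carbon ortho to a large group, two atoms from the ring nitrogen, methylsulfonyl in place of fluoro gives, in this assay, a 5.7-fold higher number from compound 1 to compound 4 (0.75 log units; beyond the scatter). This is the first direct reading at this position on the six-membered aromatic ring with 1 nitrogen, as the earlier single-place fluoro replacement, a 5.9-fold higher number from compound 2 to compound 3 (0.77 log units; beyond the scatter), belongs to the 2-fluorophenyl compound, and both steps now raise the number, with no pair shown going against this. No measurement shown gives a reason for the step at this position.

The exchange brings in more heavy atoms and two hydrogen-bond acceptors together, so the compounds shown do not separate the contribution of size from that of the sulfonyl oxygens. Open readings at this position include methyl, chloro, a nitrile, an amine and a carboxylic acid, along with methylsulfanyl on the nitrogen-containing ring and methylsulfonyl on the phenyl ring, which would show whether the two aryl groups respond alike to the same group.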